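This account rests on a few compounds, and the source may have more. Where it says the series, first, only, none or still open, it means among the compounds named here.

Compound 1 `CN(C)CCNc1ccnc2cc(OCc3ccc(F)cc3)ccc12` is one of two compounds tested in a functional assay on SK-OV-3 cells (Homo sapiens) for cytotoxicity, read by MTT assay, with a stated time of 48 h (a higher number here means a weaker inhibitor, a lower number a stronger inhibitor), where compound 1 gives 890 nM. The other is compound 2 `C=CCOc1ccc2c(NCCN(C)C)ccnc2c1`, for which this assay gives 1560 nM. Of these two numbers, that of compound 1 is the lower, but the step of a 1.8-fold higher number from compound 1 to compound 2 (0.24 log units; within the scatter) is small, so the two compounds cannot be told apart on this evidence.

Compound 3 `CN(C)CCCNc1ccnc2cc(OCc3ccc(F)cc3)ccc12` differs from compound 1 by (dimethylamino)methyl in place of dimethylamino on a saturated chain carbon, two bonds along the chain from a nitrogen on an aromatic ring; the side chain that carries the dimethylamino group is thus made longer by one carbon while the rest of the molecule stays the same.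

Among the compounds with values here, no measured step touches this side chain: the single step available, from compound 1 to compound 2, alters the group on the other side of the shared core and stays within the scatter. With nothing to suggest that lengthening the chain moves the number far, the step of a 1.1-fold higher number from compound 1 to compound 3 (0.05 log units; within the scatter) is expected to remain small. Compound 3 is therefore estimated to give 1000 nM in this assay, with a range from 400 nM to 2500 nM.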

Compound 3, half-maximal inhibitory concentration: 1280 nM
The estimate for compound 3 lay 1.3-fold (0.11 log units) below the measured number, within the range that was stated.
By their numbers in this assay, from the lowest: compounds 1, 3 and 2 (each within the scatter of the next).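

The side chain now has its first measured step: in this assay, replacing (2-(dimethylamino)ethyl)amino with (3-(dimethylamino)propyl)amino gives a 1.4-fold higher number from compound 1 to compound 3 (0.16 log units; within the scatter). Within the data shown here, the only earlier step concerned the group at the other end of the molecule, on the saturated chain carbon bound to an oxygen, so it said nothing about this position. This new step shows that, for this one pair, adding a single carbon to the chain does not separate the two compounds in this assay, and no available evidence bears on this result.

The compounds shown leave open whether a longer chain, such as 4-(dimethylamino)butyl, would remain as close to compound 1, and whether a different amine at the end of the chain, such as piperidine or morpholine, would give a step beyond the scatter. Among these compounds, the added carbon is also seen only with the 4-fluorophenyl group in place, so the size of the same step in a compound carrying the vinyl group of compound 2 remains unknown.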